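The source may hold more compounds than are shown below. What is called first, only, known or untested is meant among the compounds shown, and "the series" means these compounds.

Measured compounds:

Compound 1 `Cc1ccc(-c2nn(-c3ccccc3)cc2C(=O)NOCc2ccccc2F)cc1`: 2110 nM
Compound 2 `Cc1ccc(-c2nn(-c3ccccc3)cc2C(=O)NOCc2ccc(Cl)cc2Cl)cc1`: 2310 nM
Compound 3 `COc1ccc(-c2nn(-c3ccccc3)cc2C(=O)NOCc2ccccc2F)cc1`: 6000 nM

All three were tested in a functional assay on MCF7 cells (Homo sapiens) for antiproliferative activity, read by MTT assay, with a stated time of 48 h, in the presence of a further agent that is not named here; a higher number here means a weaker inhibitor of growth, a lower number a stronger inhibitor of growth. Compound 3 gives the highest number of the three, that is, the weakest growth inhibition. The step that separates it from the methyl analogue is a 2.8-fold higher number from compound 1 to compound 3 (0.45 log units; beyond the scatter), which comes from swapping a methyl for a methoxy on the aromatic ring attached to the shared core. Compound 2 gives a lower number than compound 3 as well, as the two values show.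

Compound 4 `COc1ccc(-c2nn(-c3ccccc3)cc2C(=O)NOCc2ccc(Cl)cc2Cl)cc1` is not yet measured. It differs from compound 3 in one place: 2,4-dichlorophenyl in place of 2-fluorophenyl on a saturated chain carbon bound to an oxygen. The very same exchange has been seen once before, where it gave a 1.1-fold higher number from compound 1 to compound 2 (0.04 log units; within the scatter), a change that stays within the usual scatter of this assay. Among the measured compounds shown here, nothing further is known about this exchange on the methoxy-bearing series, so the one precedent is the only guide. On that basis the step from compound 3 to compound 4 is expected to be small, a 1.1-fold higher number from compound 3 to compound 4 (0.03 log units; within the scatter), with no direction that can be told apart from noise.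

Compound 4 is therefore estimated at 6500 nM, with a likely range from 3000 nM to 14000 nM.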

Compound 4, concentration for 50% growth inhibition: 2570 nM
The estimate for compound 4 lay 2.5-fold (0.40 log units) above the measured number; the measured number lies below the stated range.
By their numbers in this assay, from the lowest: compounds 1, 2 and 4 (each within the scatter of the next); then compound 3.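

In this assay, among the compounds shown here, 2,4-dichlorophenyl in place of 2-fluorophenyl on a saturated chain carbon bound to an oxygen is no longer a silent exchange when the aromatic carbon carries methoxy: it gives a 2.3-fold lower number from compound 3 to compound 4 (0.37 log units; beyond the scatter), whereas its only earlier example stayed within the scatter. The methoxy in place of methyl exchange, which had raised the number in the 2-fluorophenyl pair, gives a 1.1-fold higher number from compound 2 to compound 4 (0.05 log units; within the scatter) when 2,4-dichlorophenyl is present, so the earlier loss of growth inhibition does not carry over to this pair. The two exchanges may therefore depend on each other, but that reading is not firm, since the gap between the two steps does not exceed what two such steps can scatter by: the same change on two cores in this assay, a 1.1-fold higher number (0.04 log units; within the scatter) from compound 1 to compound 2 and a 2.3-fold lower number (0.37 log units; beyond the scatter) from compound 3 to compound 4, 2.6-fold (0.41 log units) apart, within the scatter of two such steps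

Going by these compounds, with a single pair on each core, whether the effect of one exchange truly depends on the other remains open. Also open, on these data alone, is how a phenyl ring bearing one chlorine, an amine or a carboxylic acid would behave in place of the 2,4-dichlorophenyl on this saturated chain carbon.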